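This account rests on a few compounds, and the source may have more. Where it says the series, first, only, none or still open, it means among the compounds named here.

Of the compounds shown here, three sharing one core have been tested in an ADME assay on microsomes from liver (Homo sapiens) for metabolic stability; a higher number here means that the compound lasts longer, a lower number that the compound disappears faster. Compound 1 `Cc1nc(C(=O)NC(C)(C)C2CC2)c(C)c(-c2ccc(Cl)cc2)c1[C@H](OC(C)(C)C)C(=O)O` gives 3.63 h in this assay. Compound 3 `Cc1ccc2[nH]c(-c3nc(C)c([C@H](OC(C)(C)C)C(=O)O)c(-c4ccc(Cl)cc4)c3C)nc2c1` carries a 5-methyl-1H-benzimidazol-2-yl group where compound 1 carries an amide; in this assay compound 3 gives 2.77 h. The gap is a 1.3-fold lower number from compound 1 to compound 3 (0.12 log units; within the scatter), so on the numbers shown compound 3 sits together with compound 1. Compound 2 `Cc1nc(C(=O)N[C@H]2CC[C@H](O)CC2)c(C)c(-c2ccc(Cl)cc2)c1[C@H](OC(C)(C)C)C(=O)O` reaches a limit of this assay, > 5 h, a limit and not a number. In this assay the limit of > 5 h in this assay, at which 1 of the 3 values shown sits, marks where compound 2 rests. From compound 2 to compound 3 the change is an at least 1.8-fold lower number from compound 2 to compound 3 (0.25 log units; that floor lies within the scatter).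

Compound 4 `Cc1nc(-c2nc3cccc(C)c3n2C)c(C)c(-c2ccc(Cl)cc2)c1[C@H](OC(C)(C)C)C(=O)O` has not yet been measured. It differs from compound 3 in one place: 1,7-dimethyl-1H-benzimidazol-2-yl in place of 5-methyl-1H-benzimidazol-2-yl on an aromatic carbon. Both measured steps that end at compound 3 exchange an amide for the benzimidazole; neither alters the benzimidazole itself, so neither bears closely on this change. Those two steps were modest, one within the scatter and one resting on a floor inside it, and nothing shown points to a direction here. Compound 4 is therefore expected to give about 2.8 h in this assay, between 1.4 h and 5 h. The expected step is a 1.0-fold higher number from compound 3 to compound 4 (0.00 log units; within the scatter), none beyond the scatter.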

Compound 4, half-life: 2 h
Compound 4: middle estimate off by 1.4-fold (0.15 log units), on the high side; the measured number falls inside the stated range.
By their numbers in this assay, from the lowest: compounds 4, 3 and 1 (each within the scatter of the next). At a limit, above all of these: compound 2.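

In this assay, 1,7-dimethyl-1H-benzimidazol-2-yl has 0 hydrogen-bond donors where 5-methyl-1H-benzimidazol-2-yl has 1, yet this first change within the benzimidazole itself gives a 1.4-fold lower number from compound 3 to compound 4 (0.14 log units; within the scatter), and the comparison with the amide gives a 1.8-fold lower number from compound 1 to compound 4 (0.26 log units; within the scatter), so neither step separates the compounds. Against the hydroxylated amide, the step is an at least 2.5-fold lower number from compound 2 to compound 4 (0.39 log units; beyond the scatter), the only step among those shown that lies beyond the scatter, and it is a floor rather than an exact size. Compound 2 rests on a limit of the assay, not a number: the limit of > 5 h in this assay, at which 1 of the 4 values shown sits.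

The entering group differs from the leaving one in its methyl groups at more than one place, so the compounds shown cannot tell what the 1-methyl and the 7-methyl each contribute alone. Also open, as far as these compounds go, is whether a hydroxy group or an amine on the benzimidazole would bring the half-life in this assay up towards the limit that compound 2 reaches with its 4-hydroxycyclohexyl amide.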